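A few compounds are considered here, and "the series" means these few. Any claim that something is new, unique, unknown or untested is made for them only; others in the source may bear on it.

Measured compounds:
compound 1 `COc1cc(-c2nn(-c3cccc(NC(=O)Nc4ccc(Cl)c(Cl)c4)c3)cc2-c2ccncc2)ccc1Cl` gives 1590 nM
compound 2 `O=C(Nc1cccc(-n2cc(-c3ccncc3)c(-c3ccc(Cl)c(O)c3)n2)c1)Nc1ccc(Cl)c(Cl)c1` gives 1460 nM

Both numbers come from a functional assay on SW-620 cells (Homo sapiens) for inhibition, read by sulforhodamine B assay, with a stated time of 48 h; on this read-out higher numbers stand for weaker inhibition of growth and lower numbers for stronger inhibition of growth. Compound 1 stands at the higher of the two numbers shown, with compound 2 nearest; the step of a 1.1-fold lower number from compound 1 to compound 2 (0.04 log units; within the scatter) is within the scatter, so no order between the two can be stated. That step is a hydrogen in place of methyl on an oxygen on an aromatic ring, at the opposite end of the shared core from the urea-side aryl.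

Compound 3 `COc1cc(-c2nn(-c3cccc(NC(=O)Nc4ccc(Cl)c(C(F)(F)F)c4)c3)cc2-c2ccncc2)ccc1Cl` is not yet measured in this assay. Against compound 1 the change is trifluoromethyl in place of chloro on an aromatic carbon. Going by the values given here, no measured pair shows this change, and no measured pair touches the urea-side aryl at all; the only step available, a 1.1-fold lower number from compound 1 to compound 2 (0.04 log units; within the scatter), concerns another part of the molecule and was within the scatter. There is therefore no basis for expecting a step in either direction beyond the scatter, and the range has to be kept wide for lack of a direct comparison. The expected step is a 1.1-fold lower number from compound 1 to compound 3 (0.03 log units; within the scatter). Compound 3 is estimated at 1500 nM, with a range from 450 nM to 5000 nM.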

Compound 3, concentration for 50% growth inhibition: 1290 nM
Estimate against measurement, compound 3: 1.2-fold (0.07 log units) above; low and high end bracket the measured number.
By their numbers in this assay, from the lowest: compounds 3, 2 and 1 (each within the scatter of the next).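

Going by these compounds alone, the urea-side aryl is touched here for the first time: in this assay, the exchange of 3,4-dichlorophenyl for 4-chloro-3-(trifluoromethyl)phenyl gives a 1.2-fold lower number from compound 1 to compound 3 (0.09 log units; within the scatter) and so stays within the scatter. At this aromatic carbon, ortho to a chloro group and meta to a large group, trifluoromethyl with its 4 heavy atoms therefore stands in place of a single chlorine without a readable shift in growth inhibition, something the earlier pair, changed only at the other end of the shared core, could not show. No accompanying measurement bears on why the number holds, so the result stands as an observation only.

The compounds shown carry only chloro or trifluoromethyl at this position, so it remains open whether an amine, a carboxylic acid or a longer alkyl chain there would move the number beyond the scatter. As far as these compounds go, it also remains open whether the same exchange would read alike on compound 2, which carries the hydroxyl in place of the methoxy group at the far end of the molecule.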